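A few compounds are considered here, and "the series" means these few. Any claim that something is new, unique, unknown or untested is made for them only; others in the source may bear on it.

The measured compounds: compound 1 `CNC(=O)c1cc(Oc2ccc(Nc3nccc(N4CCCC4)n3)cc2)ccn1`, compound 2 `CN(c1ccc(Oc2ncnc3sccc23)cc1)c1nccc(N2CCCC2)n1`, compound 3 `CNC(=O)c1cc(Oc2ccc(Nc3nccc(N4CCCCC4)n3)cc2)ccn1`.

In a functional assay on HCT-116 cells (Homo sapiens) for inhibition, read by MTT assay, with a stated time of 72 h, tested at 20 uM (a lower number here means less inhibition, a higher number more inhibition at the concentration tested (going by the name of the read-out)), compound 1 gives 66.4%, compound 3 gives 69.8% and compound 2 gives 42.2%. Compound 2 shows the lowest number of the three, beyond the scatter from both compound 1 and compound 3. The difference between the core of compound 1 and the core of compound 2 is not broken down here. Between compound 1 and compound 3 a single change is made, (piperidin-1-yl in place of pyrrolidin-1-yl on an aromatic carbon), and in this assay this change gives a number 3.4 percentage points higher from compound 1 to compound 3 (within the scatter). Compound 4 `CN(c1ccc(Oc2ncnc3sccc23)cc1)c1nccc(N2CCCCC2)n1` is not yet measured; it differs from compound 2 by piperidin-1-yl in place of pyrrolidin-1-yl on an aromatic carbon, the same change at the same place. A step of about a number 2.8 percentage points higher from compound 2 to compound 4 (within the scatter) in this assay is expected, because on the other core the same change gave a number 3.4 percentage points higher from compound 1 to compound 3 (within the scatter). That expectation rests on one observed step only, so the range is kept wide. Compound 4 is therefore estimated at 45% in this assay, with a range from 30% to 60%.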

Compound 4, a percentage reported as inhibition, at one concentration (the size of the read-out at that concentration, not a potency): 52.2%
The estimate for compound 4 lay 7.2 percentage points below the measured number; the measured number falls inside the stated range.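

In this assay, the exchange of pyrrolidin-1-yl for piperidin-1-yl on the core of compound 2 gives a number 10 percentage points higher from compound 2 to compound 4 (within the scatter), and the two steps now available can be set side by side: the same change on two cores in this assay, a number 3.4 percentage points higher (within the scatter) from compound 1 to compound 3 and a number 10 percentage points higher (within the scatter) from compound 2 to compound 4, 6.6 percentage points apart, within the scatter of two such steps. Going by these compounds alone, on these two cores, then, the change carries over with no difference between the steps that stands out from the scatter. This does not show that the change itself raises the number, as neither step lies beyond the scatter, and two cores say nothing about how it would read on a third.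

The compounds shown leave open how other groups would read on this aromatic carbon, such as morpholin-4-yl, an open-chain dimethylamino group or a piperazine. They also leave open which part of the difference between the core of compound 1 and the core of compound 2 goes with the numbers, for instance what a hydrogen in place of the methyl on the linking nitrogen of compound 2 would give.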